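The source may hold more compounds than are shown below. What is called first, only, known or untested is meant among the compounds shown, and "the series" means these compounds.

Measured compounds in a functional assay on HEL cells (Homo sapiens), read by microscopy; on this read-out lower numbers stand for higher toxicity in this test and higher numbers for lower toxicity in this test:
Compound 1 `CCCCCCC#Cc1cc2cn(COCCO)c(=O)nc2o1`: the reported figure is a limit of the assay, > 200000 nM.
Compound 2 `CCCCCCc1cc2cn(COCCO)c(O)nc-2n1`: again only a limit of the assay, > 400000 nM.
Compound 3 `CCCCCc1cc2cn(COCCO)c(=O)nc2o1`: again only a limit of the assay, > 400000 nM.

None of the three gives a number in this assay. Compound 1 sits at the limit marked by the limit of > 200000 nM in this assay, at which 1 of the 3 values shown sits, while the other two sit at the higher limit marked by the limit of > 400000 nM in this assay, at which 2 of the 3 values shown sit; whether the two limits differ in any real sense cannot be told, since no numbers were reached. Among the measured compounds shown here, no step between measured compounds can be worked out here.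

Compound 4 `CCCCCCCCCC#Cc1cc2cn(COCCO)c(=O)nc2o1` has not been measured. It differs from compound 1 by propyl in place of hydrogen on a saturated chain carbon, six bonds along the chain from a triple-bonded carbon. With compound 1 at a limit, the expected step of a number no higher from compound 1 to compound 4 (the limit leaves the size open) is taken as none beyond the scatter, in the sense that a limit is again the most likely outcome. The estimate for compound 4 in this assay is 200000 nM, with a range from 50000 nM to 400000 nM.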

Compound 4, minimum cytotoxic concentration: >= 20000 nM
Compound 4: no number, only a limit (the forecaster's own chance of this, stated with the estimate: 65%); the middle value is on the limit's open side.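

In this assay compound 1 and compound 4 stand only as limits, and the step between them cannot be read. Left open in this assay is whether any compound shown reaches an actual number, and whether propyl in place of hydrogen changes the read-out at all.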